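The source may report more compounds than this note shows. Statements on the series, on what has been measured and on what is new or still open speak of the compounds shown alone.

Of the compounds shown here, two that share one core have been measured in an assay on isolated protein for inhibition of Amine oxidase [flavin-containing] B (Homo sapiens), read by Amplex Red; a lower number here means a stronger inhibitor, a higher number a weaker inhibitor. Compound 1 `NC/C=C(/F)COc1ccc(C(F)(F)F)cc1` carries a trifluoromethyl group on its aromatic ring, and in this assay compound 1 gives 130 nM. Compound 2 `NC/C=C(/F)COc1ccc(C(N)=O)cc1` carries a carbamoyl group in the same position. In this assay compound 2 returns > 30000 nM, and this figure is a limit of the assay rather than a number (the limit of > 30000 nM in this assay, at which 1 of the 2 values shown sits). Among the measured compounds shown here, the single measured step, an at least 230-fold higher number from compound 1 to compound 2 (2.36 log units; beyond the scatter), is a large loss of inhibition. Compound 3 `NC/C=C(/F)COc1ccc(C(=O)NCc2ccccc2)cc1` differs from compound 2 in one place: benzyl in place of hydrogen on an amide-type nitrogen. For the measured compounds named here, no measured step concerns a change on the amide nitrogen, so the only anchor is the weak position of compound 2 itself. Compound 3 is therefore expected to remain a weak inhibitor in this assay, with the step of an at least 1.5-fold lower number from compound 2 to compound 3 (0.17 log units; that floor lies within the scatter) estimated as small and quite possibly within the scatter, since a limit gives no firm starting number. For compound 3 the estimate in this assay is 20000 nM, within a range from 3000 nM to 100000 nM.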

Compound 3, half-maximal inhibitory concentration: 620 nM
Estimate against measurement, compound 3: 32-fold (1.51 log units) above; the measured number lies below the stated range.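

The amide nitrogen of compound 2 turns out to be a place where a single change can matter a great deal: benzyl in place of hydrogen gives an at least 48-fold lower number from compound 2 to compound 3 (1.68 log units; beyond the scatter) in this assay. The earlier step showed only that carbamoyl on the aromatic ring goes with a large loss of inhibition, and compound 3 now shows that this loss does not extend to every amide built on the shared core, since a substituted amide can still be a clear inhibitor. The true size of the step stays unknown, and the printed figure is only a floor, because the value for compound 2 is a limit of the assay and not a number: the limit of > 30000 nM in this assay, at which 1 of the 3 values shown sits.

With benzyl as the only group shown on this nitrogen, it remains open whether the gain depends on the aromatic ring that benzyl brings or whether any carbon group would serve. A small methyl group, a phenyl ring set directly on the nitrogen, or a longer chain such as 2-phenylethyl would begin to separate these possibilities.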